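Replacing a phenol on a piperazine with a benzodioxin amide

The source may hold more compounds than are shown below. What is called first, only, known or untested is meant among the compounds shown, and "the series" means these compounds.

Of the compounds shown here, two built on the same core have been tested in a functional assay on FaDu cells (Homo sapiens) for inhibition, read by sulforhodamine B assay (on this read-out lower numbers stand for stronger inhibition and higher numbers for weaker inhibition), and both reached only the limit of that assay. Compound 1, with the structure `COC(=O)CC/C(C)=C/Cc1c(OC)c(C)c2c(c1OCC#CCN1CCN(C(c3ccc(F)cc3)c3ccc(F)cc3)CC1)C(=O)OC2`, gave > 50000 nM in this assay, which is a limit rather than a measured number. Compound 2, with the structure `COC(=O)CC/C(C)=C/Cc1c(OC)c(C)c2c(c1OCC#CCN1CCN(c3ccc(O)cc3)CC1)C(=O)OC2`, gave > 50000 nM in this assay, again a limit and not a number. Compound 2 thus stands at the limit, as does compound 1, as shown by the limit of > 50000 nM in this assay, at which 2 of the 2 values shown sit. Compound 3, with the structure `COC(=O)CC/C(C)=C/Cc1c(OC)c(C)c2c(c1OCC#CCN1CCN(C(=O)C3COc4ccccc4O3)CC1)C(=O)OC2`, is the new compound. It differs from compound 2 in one place: (2,3-dihydro-1,4-benzodioxin-2-yl)carbonyl in place of 4-hydroxyphenyl on an amine nitrogen in a ring. Going by the values given here, no measured step between two compounds of this set is available to show how large a change of this kind tends to be. The step of a number no higher from compound 2 to compound 3 (the limit leaves the size open) is therefore expected to be none beyond the usual scatter, with compound 3 most likely also reaching only the limit. Compound 3 is expected to give about 50000 nM in this assay, within a range from 15000 nM to 200000 nM.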

Compound 3, half-maximal inhibitory concentration: > 50000 nM
Compound 3: a limit, no number; the forecaster's own chance of this, stated with the estimate: 75%; the middle value sits exactly at the limit.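

In this assay compound 3 gives > 50000 nM, which is a limit and not a number. Going by these compounds alone, compound 2 also stands at a limit, so no step between compound 2 and compound 3 can be read. The compounds shown leave open how strongly any of them inhibits, and how they rank against one another, since all share one limit: the limit of > 50000 nM in this assay, at which 3 of the 3 values shown sit.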